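The source may report more compounds than this note shows. Statements on the series, on what has been measured and on what is new or still open speak of the compounds shown alone.

Measured so far in a functional assay on HepG2 cells (Homo sapiens) for inhibition, read by MTT assay, with a stated time of 72 h; a higher number here means a weaker inhibitor, a lower number a stronger inhibitor:
compound 1, `O=C(CCCCCCCN(Cc1ccc(F)cc1)c1ncc(C(=O)NCCCn2ccnc2)s1)NO`: 26000 nM
compound 2, `CC(C)CCN(CCCCCC(=O)NO)c1ncc(C(=O)NCCCn2ccnc2)s1`: 106000 nM
compound 3, `CC(C)CCN(CCCCCCC(=O)NO)c1ncc(C(=O)NCCCn2ccnc2)s1`: 24000 nM

Compound 3 gives the lowest number of the three, but its gap to compound 1 is within the scatter, so the two cannot be ordered; only compound 2 stands clearly apart, as the step of a 4.4-fold lower number from compound 2 to compound 3 (0.65 log units; beyond the scatter) shows. Compound 4, `O=C(CCCCCCN(Cc1ccc(F)cc1)c1ncc(C(=O)NCCCn2ccnc2)s1)NO`, has not been measured in this assay. Relative to compound 3 the change is 4-fluorophenyl in place of isobutyl on a saturated chain carbon bound to a nitrogen on an aromatic ring.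

Within the data shown here, no measured pair isolates this exchange at constant chain length, so nothing here tells its direction directly. Among the measured compounds shown here, compound 4 shares its 4-fluorobenzyl group with compound 1 and differs from it only in the hydroxamic acid chain being one carbon shorter; the one chain-shortening step seen, read backwards from a 4.4-fold lower number from compound 2 to compound 3 (0.65 log units; beyond the scatter), raised the number beyond the scatter. Taking the value of compound 1 as the anchor and applying a shortening of that size, compound 4 is expected to come out weaker than compound 3, with a step of about a 3.3-fold higher number from compound 3 to compound 4 (0.52 log units; beyond the scatter). The estimate for compound 4 is 80000 nM, with a range from 25000 nM to 200000 nM.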

Compound 4, half-maximal inhibitory concentration: 9400 nM
Compound 4: middle estimate off by 8.5-fold (0.93 log units), on the high side; measured number outside the range, below it.
By their numbers in this assay, from the lowest: compound 4; then compounds 3 and 1 (each within the scatter of the next); then compound 2.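

In this assay lengthening the chain does not read as a single trend: the same change on two cores in this assay, a 4.4-fold lower number (0.65 log units; beyond the scatter) from compound 2 to compound 3 and a 2.8-fold higher number (0.44 log units; beyond the scatter) from compound 4 to compound 1, 12-fold (1.09 log units) apart, beyond the scatter of two such steps. Among the 4-fluorobenzyl compounds, the shorter chain gives a 2.8-fold lower number from compound 1 to compound 4 (0.44 log units; beyond the scatter), so compound 3 and compound 4, which carry the same chain, each hold the lower number of their chain-length pair. Among these compounds, at that constant chain length, isopentyl to 4-fluorobenzyl gives a 2.6-fold lower number from compound 3 to compound 4 (0.41 log units; beyond the scatter), the first direct reading of this exchange.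

On these data alone, whether this chain length is preferred with both side groups stays open: the longest chain appears only with 4-fluorobenzyl and the shortest only with isopentyl. Also open, as far as these compounds go, is how a cyclohexylmethyl group at this position, or a carboxylic acid in place of the hydroxamic acid, would read.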